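The source may report more compounds than this note shows. Statements on the series, on what has been measured and on what is new or still open speak of the compounds shown alone.

Measured so far in a functional assay on cells (Oocyte) for inhibition of Voltage-dependent T-type calcium channel subunit alpha-1H (Homo sapiens), tested at 100 uM; on this read-out lower numbers stand for less inhibition and higher numbers for more inhibition at the one concentration tested (going by the name of the read-out):
Compound 1 `COC(=O)CC1c2ccccc2N=C(N2CCOCC2)N1c1ccccc1` gives 14%.
Compound 2 `O=C(O)CC1c2ccccc2N=C(N2CCOCC2)N1c1ccccc1` gives 9%.
Compound 3 `O=C(CC1c2ccccc2N=C(c2ccccc2)N1c1ccccc1)OCc1ccccc1` gives 14.2%.

All three compounds share one core and show only weak inhibition in this assay. Compound 3 carries the highest number of the three, yet its gaps to compound 1 and compound 2 both lie within the usual scatter, so the three cannot be told apart. Among the measured compounds shown here, the single measured step, a number 5 percentage points lower from compound 1 to compound 2 (within the scatter), concerns the ester end of the molecule and is also within the scatter.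

Compound 4 `O=C(CC1c2ccccc2N=C(N2CCOCC2)N1c1ccccc1)OCc1ccccc1` differs from compound 3 by morpholin-4-yl in place of phenyl on a carbon with a double bond to nitrogen. For the measured compounds named here, no measured step touches this part of the core, so nothing among the measured compounds points in either direction. Going by the values given here, with every number so far sitting in the same low band, compound 4 is expected to stay there, with a number 1.2 percentage points lower from compound 3 to compound 4 (within the scatter) meaning no step beyond the scatter. The estimate for compound 4 in this assay is 13%, with a range from 3% to 23%.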

Compound 4, a percentage reported as inhibition, at one concentration (the size of the read-out at that concentration, not a potency): 20.9%
The estimate for compound 4 lay 7.9 percentage points below the measured number; measured number inside the range.
By their numbers in this assay, from the lowest: compounds 2, 1, 3 and 4 (each within the scatter of the next, the first and the last beyond it).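

In this assay, morpholin-4-yl in place of phenyl on the carbon between two ring nitrogen atoms gives a number 6.7 percentage points higher from compound 3 to compound 4 (within the scatter), so the two rings cannot be told apart at this position. Benzyl in place of hydrogen on the oxygen next to a carbonyl group gives a number 11.9 percentage points higher from compound 2 to compound 4 (beyond the scatter) and is the only step here beyond the scatter, while phenyl in place of hydrogen on the saturated chain carbon bound to that oxygen gives a number 6.9 percentage points higher from compound 1 to compound 4 (within the scatter). No measurement offers an explanation for these numbers. From the compounds shown here alone, whether dimethylamino at the ring position or phenethyl on that oxygen would move the number beyond the scatter stays open.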